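Moving a trifluoromethyl on the phenyl of the hydrazone carbon

A few compounds are considered here, and "the series" means these few. Any claim that something is new, unique, unknown or untested is made for them only; others in the source may bear on it.

Compound 1 `CN(C(=O)NC(=O)c1cccc(C(F)(F)F)c1)c1nc(C(F)(F)F)c(C(=O)N/N=C/c2ccccc2C(F)(F)F)s1`: 7.69 ug/mL
Compound 2 `CN(C(=O)NC(=O)c1cccc([N+](=O)[O-])c1)c1nc(C(F)(F)F)c(C(=O)N/N=C/c2ccccc2C(F)(F)F)s1`: 4.73 ug/mL

In a functional assay on MCF7 cells (Homo sapiens) for inhibition, read by MTT assay, with a stated time of 72 h (a higher number here means a weaker inhibitor, a lower number a stronger inhibitor), compound 1 gives 7.69 ug/mL, the higher of the two numbers measured. Going by the values given here, the only step between measured compounds, a 1.6-fold lower number from compound 1 to compound 2 (0.21 log units; within the scatter), stays within the scatter, so the two numbers cannot be put in order. Compound 3 `CN(C(=O)NC(=O)c1cccc(C(F)(F)F)c1)c1nc(C(F)(F)F)c(C(=O)N/N=C/c2cccc(C(F)(F)F)c2)s1` has not been measured; it differs from compound 1 by 3-(trifluoromethyl)phenyl in place of 2-(trifluoromethyl)phenyl on a carbon with a double bond to nitrogen. Among the compounds with values here, the one measured step touches a different aromatic carbon, where nitro stands in place of trifluoromethyl, and so says nothing about the change made here. Within the data shown here, no measured step bears on it, and the data give no guide to the size or direction of its effect. Without such a guide, the step is expected to be none beyond the scatter, a 1.0-fold higher number from compound 1 to compound 3 (0.00 log units; within the scatter). Compound 3 is therefore estimated at 7.7 ug/mL, with a range from 3 ug/mL to 20 ug/mL.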

Compound 3, half-maximal inhibitory concentration: 3.7 ug/mL
Beside the measured number, compound 3's estimate is 2.1-fold (0.32 log units) above it; the range from low to high includes it.
By their numbers in this assay, from the lowest: compounds 3, 2 and 1 (each within the scatter of the next, the first and the last beyond it).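

Moving the trifluoromethyl, with 3-(trifluoromethyl)phenyl in place of 2-(trifluoromethyl)phenyl on the carbon with a double bond to nitrogen, gives a 2.1-fold lower number from compound 1 to compound 3 (0.32 log units; beyond the scatter) in this assay, a modest change. Unlike the earlier step at the other aromatic carbon, this one lies beyond the scatter, so this part of the molecule responds to where the trifluoromethyl stands on the phenyl, even though the two compounds hold the same atoms. Nothing at hand gives a reason for this step.

The compounds shown leave open whether the same move gives a similar step when the nitro of compound 2 is present on the other aromatic carbon. They also leave open how this position would respond if a methoxy group or an amine stood on the phenyl in place of the trifluoromethyl.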